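A methylamino to (cyclopropylmethyl)amino step on a shared core

The source may hold more compounds than are shown below. What is called first, only, known or untested is meant among the compounds shown, and "the series" means these compounds.

In a functional assay on NCI-H460 cells (Homo sapiens) for cytotoxicity, read by MTT assay, with a stated time of 96 h (on this read-out lower numbers stand for stronger inhibition and higher numbers for weaker inhibition), compound 1 (`COc1ncc(-c2cc(OC3CCCCC3)c3nc(N)nc(C)c3c2)cc1NS(=O)(=O)c1ccc(F)cc1F`) gives 96 nM and compound 3 (`CNc1nc(C)c2cc(-c3cnc(OC)c(NS(=O)(=O)c4ccc(F)cc4F)c3)cc(OC3CCOCC3)c2n1`) gives 59 nM in the same test, two values within the scatter of each other. Compound 2 (`COc1ncc(-c2cc(OC3CCOCC3)c3nc(N)nc(C)c3c2)cc1NS(C)(=O)=O`) reads 860 nM on the same scale, a higher number that lies beyond the scatter from compound 3. Compound 3 thus stands with compound 1 at the low end of the three numbers, well clear of compound 2.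

Compound 4 (`COc1ncc(-c2cc(OC3CCOCC3)c3nc(NCC4CC4)nc(C)c3c2)cc1NS(=O)(=O)c1ccc(F)cc1F`) departs from compound 3 by a single change: cyclopropyl in place of hydrogen on a saturated chain carbon bound to a nitrogen on an aromatic ring. Cut one bond further out, the same change reads methylamino to (cyclopropylmethyl)amino.

Within the data shown here, no measured pair changes only this place, so the data offer no direct step to borrow. In this assay a small step toward a higher number is expected, possibly not beyond the scatter. That expectation starts from compound 3 at 59 nM and rests on the added cyclopropyl alone, with nothing measured to fix its direction firmly. The expected size is a 1.9-fold higher number from compound 3 to compound 4 (0.27 log units; within the scatter) on this estimate. Compound 4 is expected at 110 nM in a range from 35 nM to 350 nM pending measurement.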

Compound 4, half-maximal inhibitory concentration: 410 nM
Beside the measured number, compound 4's estimate is 3.7-fold (0.57 log units) below it; the whole stated range lies below it.
By their numbers in this assay, from the lowest: compounds 3 and 1 (each within the scatter of the next); then compound 4; then compound 2.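

Among the four compounds, compound 3 and compound 4 form the only pair that differs in one place, so this is the first direct reading of a change on the saturated chain carbon bound to a nitrogen on an aromatic ring. In this assay, going from methylamino to (cyclopropylmethyl)amino gives a 6.9-fold higher number from compound 3 to compound 4 (0.84 log units; beyond the scatter), a step toward weaker inhibition that stands clear of the usual scatter and shows that the read-out responds to what this place carries, even with the rest of the molecule held fixed. Nothing shown explains this step, and the result records only its direction and size on this one pair.

From the compounds shown here alone, whether the step belongs to the three-membered ring itself or would follow any group larger than methyl remains open, and an ethylamino or isobutylamino group at this place would help to separate those two readings. A plain amino group on the core of compound 3 would also show whether methylamino is itself a gain or a loss at this place, and that direction cannot be read from the pair in hand.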